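Adding a hydroxy to compound 2

The source may report more compounds than this note shows. Statements on the series, on what has been measured and on what is new or still open speak of the compounds shown alone.

compound 1 `Cn1ccc2c(Cc3ccc(-c4nccs4)cc3)cc(C(=O)N[C@@H]3CCOC[C@H]3O)nc21`: 0.02
compound 2 `Cn1ccc(-c2ccc(Cc3cc(C(=O)NC4CCOCC4)nc4c3ccn4C)cc2)n1`: 0.04

In an ADME assay on a cell-free system (plasma, Rattus norvegicus) for protein binding, read by LC-MS, using equilibrium dialysis, with a stated time of 4 h (on this read-out lower numbers stand for a smaller free fraction and higher numbers for a larger free fraction), compound 2 (0.04) lies within the usual scatter of compound 1 (0.02), so the two cannot be told apart. Compound 3 `Cn1ccc(-c2ccc(Cc3cc(C(=O)N[C@@H]4CCOC[C@H]4O)nc4c3ccn4C)cc2)n1` differs from compound 2 by hydroxy in place of hydrogen on a saturated ring carbon. Compound 1 carries the same 3-hydroxyoxan-4-yl group but differs elsewhere too, and its 0.02 gives no hint of a large rise. The estimated step of a 1.3-fold higher number from compound 2 to compound 3 (0.10 log units; within the scatter) is a small rise in free fraction, within the usual scatter. Compound 3 is estimated at 0.05 (range 0.025 to 0.1).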

Compound 3, unbound fraction: 0.03
For compound 3 the middle estimate is 1.7-fold (0.22 log units) above the measured one; the range from low to high includes it.
By their numbers in this assay, from the lowest: compounds 1, 3 and 2 (each within the scatter of the next).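

In this assay, hydroxy in place of hydrogen on this saturated ring carbon, two ring bonds from the ring oxygen, gives a 1.3-fold lower number from compound 2 to compound 3 (0.12 log units; within the scatter), so this change leaves no readable mark on the unbound fraction. With the 3-hydroxyoxan-4-yl group kept, 1-methyl-1H-pyrazol-3-yl in place of 1,3-thiazol-2-yl gives a 1.5-fold higher number from compound 1 to compound 3 (0.18 log units; within the scatter), so that pair cannot be told apart either. Nothing measured here offers an explanation for these results. The compounds shown leave open whether an amine or a carboxylic acid on this ring carbon would give a step beyond the scatter.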